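Swapping a Flexible Side Chain for a Phenyl Ring

The source may hold more compounds than are shown below. What is called first, only, known or untested is meant among the compounds shown, and "the series" means these compounds.

Three compounds share a core in which a 4-methylpiperazin-1-yl group sits on a fused two-ring system, and they differ only in what hangs from the aromatic nitrogen. In a functional assay on ileum for inhibition of histamine H1 receptor (Cavia porcellus) (a higher number here means a weaker inhibitor, a lower number a stronger inhibitor), compound 1 `CCOCCn1c(N2CCN(C)CC2)nc2ccccc21` gives 10 nM, compound 2 `CCNCCn1c(N2CCN(C)CC2)nc2ccccc21` gives 290 nM, and compound 3 `CN1CCN(c2nc3ccccc3n2CCOCCO)CC1` gives 42 nM. Compound 3 thus holds the second highest number of the three, with compound 1 nearest and compound 2 furthest away.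

Compound 4 `CN1CCN(c2nc3ccccc3n2-c2ccccc2)CC1` makes the change (phenyl in place of 2-(2-hydroxyethoxy)ethyl on an aromatic nitrogen). For the measured compounds named here, no measured step replaces the whole chain with a ring, so the closest guides are indirect: a 4.2-fold higher number from compound 1 to compound 3 (0.62 log units; beyond the scatter) and a 29-fold higher number from compound 1 to compound 2 (1.46 log units; beyond the scatter) show that changes within this chain move the number noticeably, while a 6.9-fold lower number from compound 2 to compound 3 (0.84 log units; beyond the scatter) shows the reverse direction. Because a 4.2-fold higher number from compound 1 to compound 3 (0.62 log units; beyond the scatter) was only modest, a step of similar size in either direction is expected for compound 4, namely a 1.1-fold lower number from compound 3 to compound 4 (0.02 log units; within the scatter). Compound 4 is estimated at 40 nM, within a range from 8 nM to 200 nM.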

Compound 4, half-maximal inhibitory concentration: 760 nM
Compound 4: the middle estimate sits 19-fold (1.28 log units) below what was measured, outside the stated range (above it).
By their numbers in this assay, from the lowest: compound 1; then compound 3; then compound 2; then compound 4.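

Phenyl on the aromatic nitrogen gives the highest number of the four in this assay, and the gap to each open chain is beyond the scatter: against the 2-(2-hydroxyethoxy)ethyl chain the change gives a large step (an 18-fold higher number from compound 3 to compound 4 (1.26 log units; beyond the scatter)), against the 2-(ethylamino)ethyl chain a modest one (a 2.6-fold higher number from compound 2 to compound 4 (0.42 log units; beyond the scatter)), and against the 2-ethoxyethyl chain the largest (a 76-fold higher number from compound 1 to compound 4 (1.88 log units; beyond the scatter)). Six heavy atoms leave and six enter in the change from compound 3, so at this position a swap that keeps that count can still move the number strongly. No measurement here explains the loss.

The compounds shown cannot separate the effect of the ring itself from that of losing the chain. A benzyl or 2-phenylethyl group, which holds the phenyl ring away from the aromatic nitrogen on a carbon chain, would help to tell these apart.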